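Urea for Amide on the Naphthalene Core: An Expected Step

A few compounds are considered here, and "the series" means these few. Any claim that something is new, unique, unknown or untested is made for them only; others in the source may bear on it.

The starting point is compound 1 `CCCNC(=O)c1ccc2cc(C(O)(c3c[nH]cn3)C(C)C)ccc2c1`. In an assay on microsomes from Testis (strain Sprague-Dawley) for inhibition of steroid 17-alpha-hydroxylase/17,20 lyase (Rattus norvegicus) (on this read-out higher numbers stand for weaker inhibition and lower numbers for stronger inhibition), compound 1 gives 13 nM, the lowest of the two numbers recorded. For the measured compounds named here, the nearest comparison is compound 2 `CNC(=O)c1ccc2cc(C(O)(c3c[nH]cn3)C(C)C)ccc2c1C`, which in this assay gives 200 nM; the gap between these two values lies beyond the scatter, but the two structures differ in more than one place, so no single step between them is defined.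

The compound now in question is compound 3 `CNC(=O)Nc1ccc2cc(C(O)(c3c[nH]cn3)C(C)C)ccc2c1`. It differs from compound 1 in one place: (methylcarbamoyl)amino in place of propylcarbamoyl on an aromatic carbon. The shared core and the carbinol bearing the imidazole are unchanged.

Going by the values given here, with no measured step of this kind available, the expectation rests on compound 1 alone, whose value of 13 nM sets the anchor, and on the fact that compound 2 with its smaller amide chain and extra methyl sits well above it. A modest move toward weaker inhibition is expected, though one that could still fall inside the scatter. For compound 3 in this assay the estimate is 40 nM, with a range from 10 nM to 160 nM, corresponding to an expected step of a 3.1-fold higher number from compound 1 to compound 3 (0.49 log units; beyond the scatter).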

Compound 3, half-maximal inhibitory concentration: 11 nM
Beside the measured number, compound 3's estimate is 3.6-fold (0.56 log units) above it; the measured number falls inside the stated range.
By their numbers in this assay, from the lowest: compounds 3 and 1 (each within the scatter of the next); then compound 2.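

In this assay the exchange of propylcarbamoyl for (methylcarbamoyl)amino on this aromatic carbon gives a 1.2-fold lower number from compound 1 to compound 3 (0.07 log units; within the scatter), so the two compounds cannot be told apart on this read-out. The position thus carries either group, the one with 6 heavy atoms and 1 hydrogen-bond donor or the one with 5 heavy atoms and 2 hydrogen-bond donors, without a change beyond the scatter, something compounds differing in more than one place could not show. No measurement is at hand that accounts for this result.

Still open, on these data alone, is whether a propyl chain in place of the methyl on the (methylcarbamoyl)amino group, or a plain amine or a carboxylic acid on the same aromatic carbon, would leave the number within the scatter of compound 1. The step alters both the chain and the way the group is joined to the aromatic carbon, and the compounds shown do not separate these two changes.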